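Amino at the same place on two cores

This account rests on a few compounds, and the source may have more. Where it says the series, first, only, none or still open, it means among the compounds named here.

Compound 1 `COc1ncnc2c1c(-c1ccsc1)cn2[C@@H]1O[C@H](CO)[C@@H](O)[C@H]1O` carries the shared core of compounds 1 and 2 with a methoxy group. In a functional assay on HCT-116 cells (Homo sapiens), read by MTT assay, with a stated time of 72 h (on this read-out lower numbers stand for stronger inhibition and higher numbers for weaker inhibition), compound 1 gives 140 nM. Compound 2 `COc1nc(N)nc2c1c(-c1ccsc1)cn2[C@@H]1O[C@H](CO)[C@@H](O)[C@H]1O` differs from compound 1 only by amino in place of hydrogen on an aromatic carbon. In this assay compound 2 gives > 20000 nM, which is a limit of the assay and not a number. The step of an at least 140-fold higher number from compound 1 to compound 2 (2.15 log units; beyond the scatter) is therefore read against that limit; the lower end is fixed by the limit of > 20000 nM in this assay, at which 2 of the 3 values shown sit.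

Compound 3 `O=c1[nH]cnc2c1c(-c1cc3ccccc3o1)cn2[C@@H]1O[C@H](CO)[C@@H](O)[C@H]1O` rests on a different core; how it differs from compound 1 is not broken down here. In this assay compound 3 gives > 20000 nM, which is a limit of the assay and not a number.

Compound 4 `Nc1nc2c(c(-c3cc4ccccc4o3)cn2[C@@H]2O[C@H](CO)[C@@H](O)[C@H]2O)c(=O)[nH]1` is not yet measured. It differs from compound 3 by amino in place of hydrogen on an aromatic carbon. This is the same kind of change as that from compound 1 to compound 2, though the surroundings are not identical: on compound 1 the place is meta to a methoxy group (2 heavy atoms), whereas on compound 3 it is meta to a group of 1 heavy atom.

Among the compounds with values here, the expectation for compound 4 rests on two things: compound 3 already sits at the limit with > 20000 nM, and the only measured instance of this change, an at least 140-fold higher number from compound 1 to compound 2 (2.15 log units; beyond the scatter), made the number much higher. Compound 4 is therefore expected to stay at or beyond the limit, with an estimated step that the limit leaves unreadable from compound 3 to compound 4. Compound 4 is estimated at 40000 nM, expected to lie between 15000 nM and 150000 nM.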

Compound 4, half-maximal inhibitory concentration: > 100000 nM
Compound 4: only a limit was reported; the forecaster's own chance of this, stated with the estimate: 90%; middle value at least 2.5-fold (0.39 log units) away from the limit.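

In this assay compound 4 gives > 100000 nM, which is a limit of the assay and not a number. Within the data shown here, compound 3 also sits at a limit, so no step from compound 3 to compound 4 can be read. The compounds shown leave open what amino in place of hydrogen on an aromatic carbon does to the number on the core of compound 3, and whether the step seen on the core of compound 1 carries over to any other core.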